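Dimethylamino in place of hydrogen: compound 1 to compound 4

The source may report more compounds than this note shows. Statements on the series, on what has been measured and on what is new or still open speak of the compounds shown alone.

Compound 1 `CCOC(=O)C12C(=O)OCC=C1COC2c1ccccc1` gives 12800 nM in a functional assay on HeLa cells (Homo sapiens) for cytotoxicity, read by MTT assay (a higher number here means a weaker inhibitor, a lower number a stronger inhibitor), the highest of the three numbers recorded so far. Compound 2 `CCOC(=O)C12C(=O)OCC=C1COC2c1ccc(OC)c(OC)c1` gives 10000 nM in this assay, and compound 3 `CCOC(=O)C12C(=O)OCC=C1COC2c1cc(OC)c(OC)c(OC)c1` gives 5400 nM in this assay. The values of compound 1 and compound 2 lie within the scatter of each other, whereas the gap from compound 1 to compound 3 lies beyond it. Within the data shown here, the only measured step with a single change is a 1.9-fold lower number from compound 2 to compound 3 (0.27 log units; within the scatter), and it bears on the present step only loosely, since the entering group is not the same.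

Compound 4 `CCOC(=O)C12C(=O)OCC=C1COC2c1ccc(N(C)C)cc1` has not been measured. It differs from compound 1 by dimethylamino in place of hydrogen on an aromatic carbon. Among the measured compounds shown here, no measured step places a dimethylamino group, or any nitrogen-bearing group, on the six-membered aromatic ring of carbon only, so the sole guide is that adding methoxy groups to that ring moved the numbers little relative to compound 1. A small step is therefore expected in this assay, a 1.6-fold lower number from compound 1 to compound 4 (0.20 log units; within the scatter), toward a lower number if anything, with no firm ground for a change beyond the scatter. The estimate for compound 4 in this assay is 8000 nM, with a range of 3000 nM to 25000 nM.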

Compound 4, half-maximal inhibitory concentration: 23400 nM
Compound 4: the middle estimate sits 2.9-fold (0.47 log units) below what was measured, and the stated range covers the measured number.
By their numbers in this assay, from the lowest: compounds 3, 2, 1 and 4 (each within the scatter of the next, the first and the last beyond it).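

In this assay the series now holds a nitrogen-bearing group on the six-membered aromatic ring of carbon only, para to a large group, and dimethylamino in place of hydrogen there gives a 1.8-fold higher number from compound 1 to compound 4 (0.26 log units; within the scatter) as the whole of its step. The position therefore accepts a group of this kind, with its 3 heavy atoms and no hydrogen-bond donor, without a step that can be told apart from repeated measurement. Read beside a 1.9-fold lower number from compound 2 to compound 3 (0.27 log units; within the scatter) as the other single-place step on that ring, it makes methoxy and dimethylamino alike in one limited sense only: neither step leaves the scatter. No measurement at hand accounts for the step or ties it to any property of the group.

Open, going by these compounds, is whether a primary amine, a carboxylic acid or a longer chain on the nitrogen at this same place would stay within the scatter of compound 1 or leave it. Also open, on these data alone, is whether dimethylamino would give a comparable step on another carbon of the ring, or alongside the methoxy groups of compound 3 on the same core.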